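The source may report more compounds than this note shows. Statements on the series, on what has been measured and on what is new or still open speak of the compounds shown alone.

Compound 1 `C=C1CCC[C@]2(C)CCC(c3cn(-c4ccc(C(C)=O)cc4)nn3)=CC[C@@]12C`: 61000 nM
Compound 2 `C=C1CCC[C@]2(C)CCC(c3cn(-c4ccccc4C(C)=O)nn3)=CC[C@@]12C`: 42200 nM

Both numbers come from a functional assay on B16 cells (Mus musculus) for cytotoxicity, read by MTT assay, with a stated time of 48 h; a higher number here means a weaker inhibitor, a lower number a stronger inhibitor. Compound 2 and compound 1 lie within the scatter of each other, the step being a 1.4-fold lower number from compound 1 to compound 2 (0.16 log units; within the scatter). Compound 3 `C=C1CCC[C@]2(C)CCC(c3cn(-c4ccc(C)cc4)nn3)=CC[C@@]12C` differs from compound 2 by 4-methylphenyl in place of 2-acetylphenyl on an aromatic nitrogen. Among the measured compounds shown here, the one measured step, a 1.4-fold lower number from compound 1 to compound 2 (0.16 log units; within the scatter), only moved the acetylphenyl substitution and stayed within the scatter; nothing measured shows what removing the acetyl does. Compound 3 is therefore expected close to compound 2, at 45000 nM with a range of 18000 nM to 110000 nM. The expected step is a 1.1-fold higher number from compound 2 to compound 3 (0.03 log units; within the scatter), not beyond the scatter.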

Compound 3, half-maximal inhibitory concentration: 57600 nM
Compound 3: the middle estimate sits 1.3-fold (0.11 log units) below what was measured; the measured number falls inside the stated range.
By their numbers in this assay, from the lowest: compounds 2, 3 and 1 (each within the scatter of the next).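

Methyl in place of acetyl can now be read directly in this assay: there is a 1.1-fold lower number from compound 1 to compound 3 (0.02 log units; within the scatter), and the move to 4-methylphenyl from 2-acetylphenyl gives a 1.4-fold higher number from compound 2 to compound 3 (0.14 log units; within the scatter). So losing the acetyl, and with it the one hydrogen-bond acceptor of this group, shows no change beyond the scatter in these compounds. Nothing available explains this result. On these data alone, what stays open is whether an amine, a carboxylic acid or a longer chain in place of the methyl of compound 3 would move the number beyond the scatter.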